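A Single Added Methyl on Compound 2

This account rests on a few compounds, and the source may have more. Where it says the series, first, only, none or still open, it means among the compounds named here.

Among the measured compounds shown here, in an ADME assay on MT4 cells (Homo sapiens) for cytotoxicity, read by MTT assay, with a stated time of 4 days (on this read-out lower numbers stand for higher toxicity in this test and higher numbers for lower toxicity in this test), compound 2 `CC(C)N(C)c1nc(Cc2c(F)cccc2F)cc(=O)[nH]1` gives 85000 nM, the only actual number in this set. Compound 1 `CCN(C)c1nc(Cc2c(F)cccc2F)cc(=O)[nH]1` is known only as a limit, > 89000 nM. Compound 3 `CCCN(CCC)c1nc(Cc2c(F)cccc2F)cc(=O)[nH]1` is also known only as a limit, > 78000 nM. Compound 4 `Cc1c(Cc2c(F)cccc2F)nc(N(C)C(C)C)[nH]c1=O` differs from compound 2 by one change: methyl in place of hydrogen on an aromatic carbon. For the measured compounds named here, no measured step involves this aromatic carbon, since all of them alter the amino group. They offer only indirect guidance: an at least 1.0-fold lower number from compound 1 to compound 2 (0.01 log units; that floor lies within the scatter), then a step that the two limits leave unreadable from compound 1 to compound 3, and a step that the limit leaves unreadable from compound 2 to compound 3. With no readable step beyond the scatter, none is expected here in this assay, so the estimate is a 1.2-fold lower number from compound 2 to compound 4 (0.08 log units; within the scatter). Compound 4 is estimated at 70000 nM, with an expected range of 30000 nM to 100000 nM.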

Compound 4, half-maximal cytotoxic concentration: 79000 nM
For compound 4 the middle estimate is 1.1-fold (0.05 log units) below the measured one; the measured number falls inside the stated range.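

Among the compounds shown here, earlier compounds altered only the amino group, so compound 4 gives the first reading at this aromatic carbon. In this assay the added methyl gives a 1.1-fold lower number from compound 2 to compound 4 (0.03 log units; within the scatter) and so leaves the cytotoxicity number of compound 2 within the usual scatter. Nothing given here points to a cause for this result.

Going by these compounds, whether an amine or a carboxylic acid on this aromatic carbon would behave like methyl stays open. So does whether methyl here would give the same result with a different amino group, such as the dipropylamino group of compound 3.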